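Alkylamino chain variation on the shared core: compound 4

The source may hold more compounds than are shown below. What is called first, only, known or untested is meant among the compounds shown, and "the series" means these compounds.

The three measured compounds share one core and differ only in the chain on the ring amine. Compound 1 `CCCCNc1nnc(SCC(=O)N(Cc2cccc([N+](=O)[O-])c2)c2ccc(F)cc2)s1` gives 30% in an assay on isolated protein for inhibition of Amine oxidase [flavin-containing] A (Homo sapiens), read by fluorescence and Amplex Red, with a stated time of 30 min, tested at 0.01 uM; on this read-out lower numbers stand for a weaker effect and higher numbers for a stronger effect at the one concentration tested. Compound 2 `CCCNc1nnc(SCC(=O)N(Cc2cccc([N+](=O)[O-])c2)c2ccc(F)cc2)s1` gives 25.1%, and compound 3 `CC(C)CNc1nnc(SCC(=O)N(Cc2cccc([N+](=O)[O-])c2)c2ccc(F)cc2)s1` gives 25.5%. The steps are a number 4.9 percentage points lower from compound 1 to compound 2 (within the scatter), a number 4.5 percentage points lower from compound 1 to compound 3 (within the scatter) and a number 0.4 percentage points higher from compound 2 to compound 3 (within the scatter), so all three values sit within the scatter of one another. Compound 3 stands second highest of the three, nearest to compound 2 and furthest from compound 1, both gaps within the scatter.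

Compound 4 `COCCNc1nnc(SCC(=O)N(Cc2cccc([N+](=O)[O-])c2)c2ccc(F)cc2)s1` is unmeasured. The change from compound 3 is methoxymethyl in place of isopropyl on a saturated chain carbon bound to a nitrogen on an aromatic ring. For the measured compounds named here, the steps from compound 1 to compound 3 and from compound 2 to compound 3 touch the same chain position and were both within the scatter; no measured step introduces an oxygen into this chain, so nothing in the data points to a larger move. The expected step is a number 1.5 percentage points lower from compound 3 to compound 4 (within the scatter), within the scatter. Compound 4 is estimated at 24%, with a range from 12% to 36%.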

Compound 4, a percentage reported as inhibition, at one concentration (the size of the read-out at that concentration, not a potency): 34.8%
Estimate against measurement, compound 4: 10.8 percentage points below; low and high end bracket the measured number.
By their numbers in this assay, from the lowest: compounds 2, 3, 1 and 4 (each within the scatter of the next).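

The position takes the oxygen of 2-methoxyethyl without any step beyond the scatter: in this assay the readings are a number 9.3 percentage points higher from compound 3 to compound 4 (within the scatter) for isobutyl to 2-methoxyethyl, a number 9.7 percentage points higher from compound 2 to compound 4 (within the scatter) for methoxy in place of methyl and a number 4.8 percentage points higher from compound 1 to compound 4 (within the scatter) for methoxy in place of ethyl on the same chain. The hydrogen-bond acceptor that enters with methoxymethyl therefore leaves all four compounds within the scatter of one another, so they cannot be ranked on this read-out. Nothing available bears on this result.

Open, going by these compounds, is whether an amine or a carboxylic acid on this chain would move the reading beyond the scatter. Also open, on these data alone, is what a hydroxyl in place of the methoxy, or a longer chain such as 3-methoxypropyl, would give.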